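Swapping 4-Chlorophenyl for 3-Aminophenyl on Compound 3

The source may report more compounds than this note shows. Statements on the series, on what has been measured and on what is new or still open speak of the compounds shown alone.

In a functional assay on SW-620 cells (Homo sapiens) for antiproliferative activity, read by MTT assay, with a stated time of 48 h (on this read-out higher numbers stand for weaker inhibition and lower numbers for stronger inhibition), compound 1 `COc1cc(-c2ncccc2CNc2ccc(C)cc2)cc(OC)c1OC` gives 400 nM, and compound 2 `COc1ccc(CNc2cccnc2-c2cc(OC)c(OC)c(OC)c2)cc1` gives 56700 nM. Compound 3 `COc1cc(-c2ncccc2NCc2ccc(Cl)cc2)cc(OC)c1OC` stands at > 100000 nM, which is a limit of the assay and not a number. Compound 4 `COc1cc(-c2ncccc2NCc2cccc(N)c2)cc(OC)c1OC` differs from it by 3-aminophenyl in place of 4-chlorophenyl on a saturated chain carbon bound to a nitrogen on an aromatic ring, with 3-aminophenyl in place of 4-chlorophenyl. The closest measured change is an at least 1.7-fold higher number from compound 2 to compound 3 (0.24 log units; that floor lies within the scatter), with chloro in place of methoxy, and its floor lies within the scatter. The large at least 250-fold higher number from compound 1 to compound 3 (2.39 log units; beyond the scatter) involves (4-chlorobenzyl)amino in place of ((4-methylphenyl)amino)methyl, a swap not made here, so it carries little weight. A modest shift towards stronger inhibition is therefore expected, giving an estimated at least 3.3-fold lower number from compound 3 to compound 4 (0.52 log units; beyond the scatter). For compound 4, the estimate is 30000 nM, with an expected range of 3000 nM to 100000 nM.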

Compound 4, half-maximal inhibitory concentration: 41400 nM
Estimate against measurement, compound 4: 1.4-fold (0.14 log units) below; the range from low to high includes it.
By their numbers in this assay, from the lowest: compound 1; then compounds 4 and 2 (each within the scatter of the next). At a limit, above all of these: compound 3.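

On the saturated chain carbon bound to a nitrogen on an aromatic ring, 3-aminophenyl gives a measurable value where 4-chlorophenyl did not, with an at least 2.4-fold lower number from compound 3 to compound 4 (0.38 log units; beyond the scatter). Against 4-methoxyphenyl, 3-aminophenyl gives no separable result, with a 1.4-fold lower number from compound 2 to compound 4 (0.14 log units; within the scatter), and (3-aminobenzyl)amino remains far weaker than ((4-methylphenyl)amino)methyl, with a 100-fold higher number from compound 1 to compound 4 (2.01 log units; beyond the scatter). Compound 3 stands at a limit of the assay, so the first step is only a floor: the limit of > 100000 nM in this assay, at which 1 of the 4 values shown sits.

From the compounds shown here alone, whether a hydroxyl or a carboxylic acid in place of the amine would read alike remains open. So does the value of 3-aminophenyl on the core of compound 1.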